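Ether substituent swap on the aryl ring of compound 2

The source may hold more compounds than are shown below. What is called first, only, known or untested is meant among the compounds shown, and "the series" means these compounds.

Compound 1 `Cc1ncccc1-c1nc2cn(-c3ccccc3)nc2c(=O)n1C[C@H]1CCCN(C[C@H]2CCCO2)C1` carries an unsubstituted phenyl on the shared core; in an assay on HEK293 cells for displacement of a labelled ligand from growth hormone secretagogue receptor type 1 (Homo sapiens), with a stated time of 60 min (a higher number here means a weaker inhibitor, a lower number a stronger inhibitor), compound 1 gives 190 nM. Compound 2 `Cc1ncccc1-c1nc2cn(-c3cccc(OC(C)C)c3)nc2c(=O)n1C[C@H]1CCCN(C[C@H]2CCCO2)C1` carries isopropoxy on that phenyl; in this assay compound 2 gives 11 nM, the lowest of the three numbers shown, with compound 3 nearest and compound 1 furthest. Among the compounds with values here, compound 3 `Cc1ccccc1-c1nc2cn(-c3cccc(C#N)c3)nc2c(=O)n1CC1CCCN(C(C)C)C1` differs from compound 2 in several places at once; in this assay compound 3 gives 32 nM, and no single-change step connects it to compound 2.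

Within the data shown here, the one measured single-change step on this phenyl is a 17-fold lower number from compound 1 to compound 2 (1.24 log units; beyond the scatter), a large step. Compound 4 `Cc1ncccc1-c1nc2cn(-c3cccc(OC(F)F)c3)nc2c(=O)n1C[C@H]1CCCN(C[C@H]2CCCO2)C1` is the compound to be measured, and it differs from compound 2 thus: difluoromethyl in place of isopropyl on an oxygen on an aromatic ring. Among the measured compounds shown here, only the step from compound 1 to compound 2 bears on this change, since it concerns the same position; nothing measured tells how much of that gain rests on the group beyond the oxygen rather than on the oxygen itself. The expectation for this assay is therefore a step of modest size at most, with the direction uncertain and a somewhat higher number held more likely; the estimated step is a 1.8-fold higher number from compound 2 to compound 4 (0.26 log units; within the scatter). Compound 4 is expected to give 20 nM in this assay, within 6 nM to 70 nM.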

Compound 4, half-maximal inhibitory concentration in the growth hormone secretagogue receptor type 1 assay: 27 nM
Compound 4: the middle estimate sits 1.4-fold (0.13 log units) below what was measured, within the range that was stated.
By their numbers in the growth hormone secretagogue receptor type 1 assay, from the lowest: compound 2; then compounds 4 and 3 (each within the scatter of the next); then compound 1.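

Working notes on the ether position. In the growth hormone secretagogue receptor type 1 assay, the group beyond the oxygen clearly matters, as difluoromethyl in place of isopropyl gives a measurable loss (a 2.5-fold higher number from compound 2 to compound 4 (0.39 log units; beyond the scatter)). Much of the gain over the unsubstituted phenyl nevertheless survives the swap (a 7.0-fold lower number from compound 1 to compound 4 (0.85 log units; beyond the scatter)), so at this place the gain does not depend on isopropyl alone. In a physicochemical assay for lipophilicity, using the shake flask method, measured as octanol-water partition, with a stated time of 30 min, at pH 7.4 (on this read-out higher numbers stand for higher lipophilicity and lower numbers for lower lipophilicity), compound 2 gives 2.7 and compound 4 gives 2.2 on this read-out, so the same swap also shifts the distribution coefficient (a number 0.50 log units lower from compound 2 to compound 4 (beyond the scatter)), although one pair cannot show whether this shift has any connection with the change in the receptor assay.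

Going by these compounds, both substituted compounds in this comparison hold an oxygen on the aromatic ring, so it remains open whether the oxygen itself is needed, a question that an ethyl group or an amine at the same place would address. On these data alone, it also remains open whether the two read-outs follow each other across this position, and how far the group on the oxygen can grow, as a longer chain such as butyl would indicate.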